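A few compounds are considered here, and "the series" means these few. Any claim that something is new, unique, unknown or untested is made for them only; others in the source may bear on it.

Compound 1, `CCCCC(Sc1nc(Cl)cc(Nc2nc(-c3ccc(Cl)cc3)cs2)n1)C(=O)O`: 3800 nM
Compound 2, `CCC(Sc1nc(Cl)cc(Nc2nc(-c3ccc(Cl)cc3)cs2)n1)C(=O)O`: 6600 nM
Compound 3, `CCCCCCC(Sc1nc(Cl)cc(Nc2nc(-c3ccc(C)cc3)cs2)n1)C(=O)O`: 3000 nM

All three values come from an assay for inhibition of Polyunsaturated fatty acid 5-lipoxygenase (Homo sapiens), read by HPLC, with a stated time of 10 min; a higher number here means a weaker inhibitor, a lower number a stronger inhibitor. Compound 3 has the lowest of the three numbers; its nearest neighbour is compound 1, whose value lies within the scatter of that of compound 3, while compound 2 stands beyond the scatter above compound 3. Going by the values given here, the one measured step between neighbours, a 1.7-fold higher number from compound 1 to compound 2 (0.24 log units; within the scatter), concerns the saturated chain and is within the scatter.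

Compound 4, `CCCCCCC(Sc1nc(Cl)cc(Nc2nc(-c3ccc([N+](=O)[O-])cc3)cs2)n1)C(=O)O`, differs from compound 3 in one place: nitro in place of methyl on an aromatic carbon, so that a 4-methylphenyl becomes a 4-nitrophenyl, para to a large group. Among the compounds with values here, no measured pair in this set touches that aromatic ring; the only measured step concerns the chain and does not bear on this change. There is therefore no basis in these data for expecting a shift beyond the scatter in this assay, and the estimate for compound 4 is placed close to compound 3, with a wide range to reflect the missing comparison: compound 4 is expected at 3000 nM, between 1000 nM and 10000 nM, which corresponds to an expected step of no change at the digits printed from compound 3 to compound 4 (within the scatter).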

Compound 4, half-maximal inhibitory concentration: 1800 nM
Estimate against measurement, compound 4: 1.7-fold (0.22 log units) above; measured number inside the range.
By their numbers in this assay, from the lowest: compounds 4, 3, 1 and 2 (each within the scatter of the next, the first and the last beyond it).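

In this assay, going by these compounds alone, the change from 4-methylphenyl to 4-nitrophenyl gives a 1.7-fold lower number from compound 3 to compound 4 (0.22 log units; within the scatter) and provides the first measured comparison at this aromatic carbon. On this single pair, the two groups cannot be told apart, so a nitro group, with its three heavy atoms and two hydrogen-bond acceptors, takes the place of methyl without a step beyond the scatter. Nothing in the data accounts for this outcome.

The compounds shown leave open whether an amine, a methoxy group or a carboxylic acid on this same carbon would give a step beyond the scatter. Within the data shown here, they also leave open whether the exchange of methyl for nitro would give a similar step on a shorter chain than the one carried by compound 3 and compound 4.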